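The source may hold more compounds than are shown below. What is called first, only, known or untested is meant among the compounds shown, and "the series" means these compounds.

In an ADME assay on MT4 cells (Homo sapiens) for activation, read by MTT assay (a higher number here means that more compound is tolerated, a lower number that less compound is tolerated), the series is known so far only through limits. Compound 1 `CC(C)Sc1nc(C(C)c2c(F)cccc2Cl)cc(=O)[nH]1` gives > 75000 nM, which is a limit. Compound 2 `Cc1c(C(C)c2c(F)cccc2Cl)nc(SC(C)C)[nH]c1=O` gives > 15000 nM, which is also a limit and the only standing it has. Compound 3 `CCCCSc1nc(C(C)c2c(F)cccc2Cl)c(C)c(=O)[nH]1` gives > 1500 nM, again a limit.

The change to follow leads to compound 4 `CCc1c(C(C)c2c(F)cccc2Cl)nc(SC(C)C)[nH]c1=O`: methyl in place of hydrogen on a saturated chain carbon bound to an aromatic carbon, or methyl to ethyl. For the measured compounds named here, two measured steps bear on it: a step that the two limits leave unreadable from compound 1 to compound 2 and a step that the two limits leave unreadable from compound 2 to compound 3. Neither has a readable size, so nothing beyond the scatter is expected in this assay, and no direction is assigned. The expected step is a step that the limit leaves unreadable from compound 2 to compound 4. Compound 4 is estimated at 30000 nM, with an expected range of 8000 nM to 100000 nM.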

Compound 4, half-maximal cytotoxic concentration: > 3000 nM
Compound 4: a limit, no number; the forecaster's own chance of this, stated with the estimate: 65%; the middle value lies beyond the limit too.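

Compound 4 gives > 3000 nM, which is a limit. The steps from compound 1 and compound 2 to compound 4 cannot be read, as those values are also limits. From the compounds shown here alone, the actual half-maximal cytotoxic concentration of each compound remains open.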